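This account rests on a few compounds, and the source may have more. Where it says the series, first, only, none or still open, it means among the compounds named here.

Measured in a functional assay on MCF7 cells (Homo sapiens) for inhibition, read by sulforhodamine B assay, with a stated time of 48 h; on this read-out higher numbers stand for weaker inhibition of growth and lower numbers for stronger inhibition of growth:
- Compound 1 `c1cc(NC2=NCCO2)cc(OC2CCCC2)c1`: 62100 nM
- Compound 2 `c1cc(OC2CCCCC2)ccc1NC1=NCCO1`: 19100 nM
- Compound 3 `c1cc(NC2=NCCO2)cc(OC2CCCCC2)c1`: 15900 nM

Compound 3 and compound 2 sit at the low end of these numbers, level with each other within the usual scatter, while compound 1 has the highest number of the three.

Compound 4 `c1ccc(Oc2cccc(NC3=NCCO3)c2)cc1` keeps the core of compound 3 and makes one change: phenyl in place of cyclohexyl on an oxygen on an aromatic ring. For the measured compounds named here, one measured step bears on this place, a 3.9-fold lower number from compound 1 to compound 3 (0.59 log units; beyond the scatter), a modest change that lies beyond the scatter and came from swapping cyclopentyl for cyclohexyl. Going by the values given here, no measured compound carries an aromatic group on that oxygen, so the direction of the new step cannot be read from the data. A step no larger than that modest one is expected, and quite possibly none beyond the scatter. The estimated step is a 1.4-fold higher number from compound 3 to compound 4 (0.14 log units; within the scatter). For compound 4 the expected value is 22000 nM, with an estimated range of 9000 nM to 55000 nM.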

Compound 4, concentration for 50% growth inhibition: 12200 nM
Compound 4: middle estimate off by 1.8-fold (0.26 log units), on the high side; measured number inside the range.
By their numbers in this assay, from the lowest: compounds 4, 3 and 2 (each within the scatter of the next); then compound 1.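

In this assay, for the compounds shown here, an aromatic ring on this oxygen appears for the first time, and swapping the cyclohexyl for phenyl gives a 1.3-fold lower number from compound 3 to compound 4 (0.12 log units; within the scatter), so at this position the two six-membered rings cannot be told apart, even though one is aromatic and the other is not. Compared with the five-membered ring, phenyl gives a 5.1-fold lower number from compound 1 to compound 4 (0.71 log units; beyond the scatter), a step beyond the scatter that matches the one seen for cyclohexyl, so the advantage over cyclopentyl does not depend on having a non-aromatic ring here. No supporting data are available to explain why these rings behave as they do.

From the compounds shown here alone, the effect of a benzyl group or a pyridine ring on this oxygen remains open. So does the effect of a phenyl ring carrying an amine or a carboxylic acid.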